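Stereocentre Inversion Step in a Porcupine Inhibitor Series

The compounds below may be only part of what the source reports. "The series", "measured", "known", "first", "only" and "open" are said of these compounds alone.

Measured so far:
compound 1 `O=C(CNc1ccc(-n2ccnc2)cc1)Nc1ccc(-c2ccccc2)cc1`, in an assay on cells for inhibition of Protein-serine O-palmitoleoyltransferase porcupine (Homo sapiens), read by a luciferase reporter, with a stated time of 24 h (on this read-out lower numbers stand for stronger inhibition and higher numbers for weaker inhibition), compound 1 gives 30 nM
compound 2 `O=C(Nc1ccc(-c2ccccc2)cc1)[C@@H]1CCCN1c1ccc(-n2ccnc2)cc1`, in this assay compound 2 gives 40 nM

Compound 2 carries the higher of the two numbers in this assay, yet compound 1 sits only within the scatter of it, so the two are not separable. Compound 3 `O=C(Nc1ccc(-c2ccccc2)cc1)[C@H]1CCCN1c1ccc(-n2ccnc2)cc1` is next: the two compounds have the same atoms and bonds and differ only in configuration as drawn: 1 of 1 stereo elements differ; a stereocentre at a saturated ring carbon is drawn S in compound 2 and R in compound 3. Among the compounds with values here, no pair of measured compounds shows what such an inversion does here, so the direction is not known from the data. The step from compound 2 to compound 3 is expected to be a weakening in this assay, with wide uncertainty, a 5.0-fold higher number from compound 2 to compound 3 (0.70 log units; beyond the scatter). Compound 3 is estimated at 200 nM in this assay, within 30 nM to 2000 nM.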

Compound 3, half-maximal inhibitory concentration: 33000 nM
Compound 3: the middle estimate sits 170-fold (2.22 log units) below what was measured; measured number outside the range, above it.
By their numbers in this assay, from the lowest: compounds 1 and 2 (each within the scatter of the next); then compound 3.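

The stereocentre at the saturated ring carbon is a decisive feature in this assay: going from S to R gives an 830-fold higher number from compound 2 to compound 3 (2.92 log units; beyond the scatter). Compound 1 and compound 2 alone gave no sign that this position responds to configuration. The step can be assigned to the inversion alone because nothing else in the structure changes: the fact that compounds 2 and 3 differ only in the configuration as drawn

The compounds shown leave open how a methyl group or a carboxylic acid on this ring carbon would read in this assay. As far as these compounds go, whether the same inversion has a step of similar size with other groups elsewhere on the core also remains open.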